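Allyl(cyclopropyl)amino in Place of Dipropylamino

The source may report more compounds than this note shows. Statements on the series, on what has been measured and on what is new or still open speak of the compounds shown alone.

Two measured compounds frame this account. Compound 1 `CCCCN(CC)c1nc(C)nc(N(CC)c2ccc(OC(F)(F)F)cc2Br)n1` gives 5 nM in an assay on isolated protein for binding affinity to corticotropin-releasing factor receptor 1 (Homo sapiens); a lower number here means a stronger inhibitor, a higher number a weaker inhibitor. Compound 2 `CCCN(CCC)c1nc(C)nc(N(CC)c2ccc(C(C)C)cc2Br)n1` gives 4 nM in this assay. Compound 2 has the lowest number of the two, but the gap to compound 1 is within the usual scatter, so the two values cannot be told apart.

Compound 3 `C=CCN(c1nc(C)nc(N(CC)c2ccc(C(C)C)cc2Br)n1)C1CC1` has not yet been measured. It differs from compound 2 in one place: allyl(cyclopropyl)amino in place of dipropylamino on an aromatic carbon. The leaving and entering groups have the same count of heavy atoms, donors and acceptors, and the change sits away from the part of the molecule that compound 1 and compound 2 vary between them without a visible effect. Among the measured compounds shown here, no measured pair shows what such a swap does in this assay.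

The author expects a step from compound 2 to compound 3 of a 1.5-fold higher number from compound 2 to compound 3 (0.18 log units; within the scatter), not clearly beyond the scatter, with the number more likely a little higher than lower. Compound 3 is therefore estimated at 6 nM in this assay, in a range from 2 nM to 20 nM.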

Compound 3, inhibition constant: 5 nM
Compound 3: the middle estimate sits 1.2-fold (0.08 log units) above what was measured, and the stated range covers the measured number.
By their numbers in this assay, from the lowest: compounds 2, 1 and 3 (each within the scatter of the next).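

In this assay, the exchange of dipropylamino for allyl(cyclopropyl)amino on the aromatic carbon between two ring nitrogen atoms comes out as a 1.3-fold higher number from compound 2 to compound 3 (0.10 log units; within the scatter) and so leaves the two compounds indistinguishable. Among the compounds shown here, this is the first comparison in the account between compounds that differ in one place, and it gives the first reading at this position, where compound 1 and compound 2 could not be compared directly. It shows that, in this one pair, a group with a three-membered carbon ring and a double bond can stand where a ringless group stood without a change that can be told from the scatter, although no measurement bears on why the result came out this way.

The compounds shown leave open whether the allyl part or the cyclopropyl part would give the same reading alone, as propyl(cyclopropyl)amino and allyl(propyl)amino groups would tell. They also leave open how far this position tolerates other amines, such as morpholine or the longer dibutylamino group, and whether the same exchange reads alike with the trifluoromethoxy group of compound 1 in place of isopropyl.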